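This account rests on a few compounds, and the source may have more. Where it says the series, first, only, none or still open, it means among the compounds named here.

Measured so far:
compound 1 `Cc1ccc(-c2nc(O)c3c(n2)c(C)nn3C)cc1` gives 400 nM
compound 2 `Cc1nn(C)c2c(O)nc(-c3cccc([N+](=O)[O-])c3)nc12` gives 1200 nM

In an assay on membranes from brain for binding affinity to adenosine receptor A1 (Rattus norvegicus), read by radioligand binding (a lower number here means a stronger inhibitor, a higher number a weaker inhibitor), compound 1 holds the lower of the two numbers, and the gap to compound 2 lies beyond the usual scatter. Compound 3 `Cc1nn(C)c2c(O)nc(-c3ccc(S(=O)(=O)NCCN(C)C)cc3)nc12` is not yet measured; it differs from compound 1 by (2-(dimethylamino)ethyl)sulfamoyl in place of methyl on an aromatic carbon. Among the compounds with values here, no measured pair shows a step of this kind, so the expectation rests on the size of the change alone. A weaker number is expected for compound 3, as a step of a 3.8-fold higher number from compound 1 to compound 3 (0.57 log units; beyond the scatter) in this assay, with wide uncertainty. The estimate for compound 3 is 1500 nM, in the range 300 nM to 8000 nM.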

Compound 3, half-maximal inhibitory concentration: 68 nM
Estimate against measurement, compound 3: 22-fold (1.34 log units) above; measured number below the stated range.
By their numbers in this assay, from the lowest: compound 3; then compound 1; then compound 2.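

At this aromatic carbon, para to a large group, the series accepts much more than methyl: in this assay, (2-(dimethylamino)ethyl)sulfamoyl in place of methyl gives a 5.9-fold lower number from compound 1 to compound 3 (0.77 log units; beyond the scatter) and the lowest number of the three compounds. Within the data shown here, a substituent of 9 heavy atoms is therefore compatible with a stronger number at this place, and the earlier compounds gave no sign of this. Nothing on hand accounts for the gain.

Which part of the new group carries the step remains open. An unsubstituted sulfamoyl, a chain ending in a primary amine, or a longer chain at this place would help to separate the contributions of the sulfamoyl and the terminal dimethylamino group.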